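The source may hold more compounds than are shown below. What is called first, only, known or untested is meant among the compounds shown, and "the series" means these compounds.

Measured in a functional assay on HT-29 cells (Homo sapiens) for antiproliferative activity, read by MTT assay, with a stated time of 48 h; a higher number here means a weaker inhibitor of growth, a lower number a stronger inhibitor of growth:
- Compound 1 `S=C(Nc1ccccc1)N1N=C(c2ccccc2)CC1c1ccc2c(c1)OCCO2`: 6630 nM
- Compound 2 `S=C(Nc1ccccc1)N1N=C(c2cccc(Cl)c2)CC1c1ccc2c(c1)OCCO2`: > 200000 nM (a limit of the assay, not a number)
- Compound 3 `COc1cccc(C2=NN(C(=S)Nc3ccccc3)C(c3ccc4c(c3)OCCO4)C2)c1`: 2920 nM

Of the two true numbers in this assay, compound 1 holds the higher, and compound 3 is its nearest neighbour. Compound 2 marks (the limit of > 200000 nM in this assay, at which 1 of the 3 values shown sits).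

Compound 4 `S=C(Nc1ccccc1)N1N=C(c2ccc(OCc3ccccc3)cc2)CC1c1ccc2c(c1)OCCO2` takes the core of compound 1 and carries benzyloxy in place of hydrogen on an aromatic carbon, para to a large group (benzyloxy in place of hydrogen on an aromatic carbon).

Among the compounds with values here, two measured steps bear on this, as each also replaces a hydrogen on an aromatic carbon. Chloro in place of hydrogen gives an at least 30-fold higher number from compound 1 to compound 2 (1.47 log units; beyond the scatter), a large step. Methoxy in place of hydrogen gives a 2.3-fold lower number from compound 1 to compound 3 (0.36 log units; beyond the scatter), a modest step in the opposite direction. These two steps disagree in direction, so neither sets a firm trend. Benzyloxy joins the aromatic carbon through oxygen as methoxy does, which favours the milder outcome seen with compound 3 at 2920 nM, but it is a much bigger group.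

In this assay the expected result is a 1.1-fold lower number from compound 1 to compound 4 (0.04 log units; within the scatter), with no clear shift beyond the scatter, though the uncertainty leans towards higher numbers. For compound 4 the estimated value is 6000 nM, with an expected range from 1500 nM to 40000 nM.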

Compound 4, concentration for 50% growth inhibition: 860 nM
The estimate for compound 4 lay 7.0-fold (0.84 log units) above the measured number, and the stated range ends above it.
By their numbers in this assay, from the lowest: compound 4; then compound 3; then compound 1. At a limit, above all of these: compound 2.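

In this assay, benzyloxy in place of hydrogen gives a 7.7-fold lower number from compound 1 to compound 4 (0.89 log units; beyond the scatter), so this position on the aromatic ring accepts a group that brings a whole further aromatic ring, and growth inhibition gets stronger rather than being lost. Methoxy in place of hydrogen also lowers the number, with a 2.3-fold lower number from compound 1 to compound 3 (0.36 log units; beyond the scatter), so both groups joined through oxygen move the same way, while compound 2, which carries chloro, goes against this pattern. Nothing in the data shown explains why benzyloxy lowers the number.

The compounds shown leave open whether the oxygen link or the further aromatic ring matters more, a question that a plain butyl chain or a phenyl group joined directly at this position could help to answer. They also leave open how far the change depends on where the group sits and on what it carries, since neither an amine nor a carboxylic acid on the added aromatic ring is among them, and no single group appears at two different positions.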